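Compound 3: isopropyl in place of 2-phenylpropyl

The source may hold more compounds than are shown below. What is called first, only, known or untested is meant among the compounds shown, and "the series" means these compounds.

Measured so far:
- compound 1 `C=CS(=O)(=O)NC/C=C/c1cc(OC)cc(O)c1C(=O)OC(C)C` gives 14700 nM
- compound 2 `COc1cc(O)c(C(=O)OCC(C)c2ccccc2)c(/C=C/CN2C(=O)C=CC2=O)c1` gives > 10000 nM as a limit

In a functional assay on THP-1 cells (Homo sapiens) for antiproliferative activity, read by luminescence, with a stated time of 72 h (on this read-out lower numbers stand for stronger inhibition and higher numbers for weaker inhibition), compound 2 stands at > 10000 nM, which is a limit of the assay and not a number. Compound 3 `COc1cc(O)c(C(=O)OC(C)C)c(/C=C/CN2C(=O)C=CC2=O)c1` differs from it by isopropyl in place of 2-phenylpropyl on an oxygen next to a carbonyl group and is otherwise the same. Compound 1 also carries isopropyl there and gives 14700 nM in this assay, so no large gain is expected. The expected change an at least 1.2-fold lower number from compound 2 to compound 3 (0.09 log units; that floor lies within the scatter) is a small one towards stronger inhibition, perhaps none beyond the scatter. Compound 3 is estimated at 8000 nM (expected range 2500 nM to 25000 nM).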

Compound 3, half-maximal inhibitory concentration: 7320 nM
Estimate against measurement, compound 3: 1.1-fold (0.04 log units) above, within the range that was stated.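

In this assay isopropyl in place of 2-phenylpropyl on an oxygen next to a carbonyl group gives an at least 1.3-fold lower number from compound 2 to compound 3 (0.13 log units; that floor lies within the scatter) and so fixes only a floor for this change. The true size of the step stays unread because compound 2 stands at a limit of the assay and not at a number: the limit of > 10000 nM in this assay, at which 1 of the 3 values shown sits.

With isopropyl kept, the group of 7 heavy atoms in place of the group of 6 heavy atoms gives a 2.0-fold lower number from compound 1 to compound 3 (0.30 log units; within the scatter) and these two groups are not told apart here. Open, as far as these compounds go, is how a longer chain on that oxygen reads in this assay and what an amine on the saturated chain carbon does to the number.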